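Swapping a phenyl for a chloropyridine in a cytotoxicity series

A few compounds are considered here, and "the series" means these few. Any claim that something is new, unique, unknown or untested is made for them only; others in the source may bear on it.

Of the compounds shown here, three have been measured in an ADME assay on A549 cells (Homo sapiens) for cytotoxicity, read by resazurin assay, with a stated time of 48 h; a lower number here means that less compound is tolerated, a higher number that more compound is tolerated. Compound 1 `O=C(Nc1ccc(NCC2CCCC2)cc1Cl)c1cc(Cl)ccc1O` gives 21500 nM. Compound 2 `CCN(CC)c1ccc(NC(=O)c2cc(Cl)ccc2O)c(Cl)c1` gives 55500 nM. Compound 3 `O=C(Nc1ccc(NCc2ccccc2)cc1Cl)c1cc(Cl)ccc1O` gives 19700 nM.

Compound 3 holds the lowest of the three numbers. Its nearest neighbour is compound 1, and that gap, a 1.1-fold lower number from compound 1 to compound 3 (0.04 log units; within the scatter), lies within the scatter, so the two cannot be ranked. Compound 2 stands further off: a 2.8-fold lower number from compound 2 to compound 3 (0.45 log units; beyond the scatter).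

Compound 4 `O=C(Nc1ccc(NCc2cnccc2Cl)cc1Cl)c1cc(Cl)ccc1O` is not yet measured. It differs from compound 3 in one place: 4-chloropyridin-3-yl in place of phenyl on a saturated chain carbon bound to a nitrogen on an aromatic ring. Within the data shown here, the only measured step at that same place is the one from cyclopentyl to phenyl, a 1.1-fold lower number from compound 1 to compound 3 (0.04 log units; within the scatter), which was within the scatter. The other two steps, a 2.6-fold higher number from compound 1 to compound 2 (0.41 log units; beyond the scatter) and a 2.8-fold lower number from compound 2 to compound 3 (0.45 log units; beyond the scatter), changed the whole group on the aromatic nitrogen and so bear less directly on this exchange. Among the measured compounds shown here, no measured step swaps a phenyl for a pyridine ring. On this basis no step beyond the scatter is expected for a 1.0-fold higher number from compound 3 to compound 4 (0.01 log units; within the scatter). Compound 4 is therefore estimated at 20000 nM, with a range from 9000 nM to 45000 nM.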

Compound 4, half-maximal cytotoxic concentration: 126000 nM
Estimate against measurement, compound 4: 6.3-fold (0.80 log units) below, and the stated range ends below it.
By their numbers in this assay, from the lowest: compounds 3 and 1 (each within the scatter of the next); then compound 2; then compound 4.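

In this assay, the ring on the saturated chain carbon bound to a nitrogen on an aromatic ring can matter a good deal. Going from cyclopentyl to phenyl there gave no change beyond the scatter, yet the exchange of phenyl for 4-chloropyridin-3-yl gives a 6.4-fold higher number from compound 3 to compound 4 (0.81 log units; beyond the scatter). The new group also stands apart from the earlier groups, with a 5.9-fold higher number from compound 1 to compound 4 (0.77 log units; beyond the scatter) and a 2.3-fold higher number from compound 2 to compound 4 (0.36 log units; beyond the scatter), so compound 4 now has the highest number of the series, a place compound 2 held before.

No measured evidence shown here accounts for this rise. Among these compounds, the single exchange adds both a ring nitrogen and a chlorine, and an unsubstituted pyridine ring or a chlorophenyl ring at the same place would be needed to tell their contributions apart.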